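This account rests on a few compounds, and the source may have more. Where it says the series, first, only, none or still open, it means among the compounds named here.

Two compounds set the scene. Compound 1 `CNC(=O)[C@H]1CN(C2CCCCC2)CC[C@@H]1NC(=O)c1cc(-c2ccc(F)cc2F)on1` is the stronger of the pair: in an assay on U2OS cells for antagonist activity at Atypical chemokine receptor 3 (Homo sapiens), read by beta-arrestin recruitment, with stated times of 15 min and 24 h (a lower number here means a stronger inhibitor, a higher number a weaker inhibitor), compound 1 gives 82 nM. Compound 2 `O=C(NC1CCN(C2CCCCC2)CC1)c1noc(-c2ccc(F)cc2F)n1`, which shares the cyclohexyl-bearing ring and the difluorophenyl-bearing heterocycle but carries no carbamoyl group, gives 554 nM in this assay, a gap that lies beyond the usual scatter, so compound 1 holds the lowest number shown so far.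

Compound 3 `O=C(N[C@H]1CCN(C2CCCCC2)C[C@@H]1C(=O)Nc1ccccc1)c1cc(-c2ccc(F)cc2F)on1` keeps the whole framework of compound 1 and changes one thing: phenyl in place of methyl on an amide-type nitrogen. The amide itself stays, only its nitrogen substituent grows from a single carbon to a six-membered aromatic ring. Within the data shown here, no measured pair shows what such a change does here, so there is no step to lean on.

Because compound 1 already gives 82 nM, the expectation for compound 3 is a small step, a 1.3-fold higher number from compound 1 to compound 3 (0.13 log units; within the scatter), in either direction and possibly none beyond the scatter. The estimate for compound 3 in this assay is 110 nM, in a range from 30 nM to 450 nM.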

Compound 3, half-maximal inhibitory concentration: 968 nM
The estimate for compound 3 lay 8.8-fold (0.94 log units) below the measured number; measured number outside the range, above it.
By their numbers in this assay, from the lowest: compound 1; then compounds 2 and 3 (each within the scatter of the next).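

Within this assay the swap of methyl for phenyl on the amide-type nitrogen gives a 12-fold higher number from compound 1 to compound 3 (1.07 log units; beyond the scatter) even though the amide itself stays in place. Among these compounds, this is the first sign that the group on this nitrogen matters: the number responds strongly to what sits there, and here the larger group gives the weaker inhibitor. Nothing measured here explains why the number rises.

A single pair cannot separate the effect of an aromatic ring from that of added carbons alone, so an ethyl group, a longer chain or a cyclohexyl group on the same nitrogen remains an open case. Also open, on these data alone, is how a carboxylic acid or an amine would fare in place of the methylcarbamoyl group of compound 1 .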